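Dropping the Chloro from a Hydrazone Side Chain

The compounds below may be only part of what the source reports. "The series", "measured", "known", "first", "only" and "open" are said of these compounds alone.

Compound 1, `COc1ccc(OC)c(/C=C/c2nnc(Nc3ccc(Cl)cc3)o2)c1`: > 100000 nM (a limit)
Compound 2, `COc1ccc(OC)c(/C=C/C(=O)N/N=C/c2ccc(Cl)cc2)c1`: 1190 nM

In a functional assay on HCC 2998 cells (Homo sapiens) for antiproliferative activity, read by sulforhodamine B assay, with a stated time of 48 h (a lower number here means a stronger inhibitor of growth, a higher number a weaker inhibitor of growth), compound 1 gives > 100000 nM, which is a limit of the assay rather than a number; this is the limit of > 100000 nM in this assay, at which 1 of the 2 values shown sits. In this assay, for the measured compounds named here, compound 2 gives 1190 nM, the only real number so far. Compound 3, `COc1ccc(OC)c(/C=C/C(=O)N/N=C/c2ccccc2)c1`, is not yet measured. It differs from compound 2 by hydrogen in place of chloro on an aromatic carbon, at a place para to a large group, so that 4-chlorophenyl becomes phenyl. No measured step of this kind exists among these compounds, so its size can only be judged loosely. The step of a 2.1-fold higher number from compound 2 to compound 3 (0.32 log units; beyond the scatter) is expected to be a modest weakening, perhaps not far beyond the usual scatter. Compound 3 is estimated at 2500 nM, within 800 nM to 8000 nM.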

Compound 3, concentration for total growth inhibition: 21000 nM
Estimate against measurement, compound 3: 8.4-fold (0.92 log units) below; measured number outside the range, above it.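

In this assay putting hydrogen in place of chloro gives an 18-fold higher number from compound 2 to compound 3 (1.25 log units; beyond the scatter) and so counts as a large change from the loss of one heavy atom. For the compounds shown here, until now compound 2 was the only compound with a real number, so nothing showed how much its 4-chlorophenyl end mattered; this pair shows that, in this series, 4-chlorophenyl gives clearly stronger growth inhibition than phenyl. Nothing measured here explains why this single change has so large an effect.

From the compounds shown here alone, only chloro and hydrogen can be compared at this place, so it remains open whether a bromo, a methyl or an amino group there would behave like chloro or like hydrogen. Going by these compounds, it also remains open whether chloro would have a similar effect elsewhere on the same ring.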